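This account rests on a few compounds, and the source may have more. Where it says the series, first, only, none or still open, it means among the compounds named here.

Measured in a functional assay on HCT-116 cells (Homo sapiens) for cytotoxicity, read by MTT assay, with a stated time of 48 h; on this read-out lower numbers stand for stronger inhibition and higher numbers for weaker inhibition:
compound 1 `CCOc1ccc(NC(=O)c2cn(-c3ccccc3)nc2-c2ccc(C)cc2)cc1` gives 780 nM;
compound 2 `O=C(Nc1ccc(Cl)cc1)c1cn(-c2ccccc2)nc1-c1ccc(Cl)cc1` gives 2990 nM;
compound 3 `O=C(Nc1ccc(Br)cc1)c1cn(-c2ccccc2)nc1-c1ccc(Cl)cc1` gives 4360 nM.

Compound 3 stands highest of the three numbers. Compound 2 sits nearest, with a 1.5-fold higher number from compound 2 to compound 3 (0.16 log units; within the scatter) within the scatter; compound 1 lies furthest, a gap beyond the scatter. Compound 4 `CCOc1ccc(NC(=O)c2cn(-c3ccccc3)nc2-c2ccc(Cl)cc2)cc1` carries ethoxy in place of bromo on an aromatic carbon. Within the data shown here, no measured step covers this exchange directly; the only step available, a 1.5-fold higher number from compound 2 to compound 3 (0.16 log units; within the scatter), trades one halogen for another and says little about an ethoxy group. Compound 1, which also carries a (4-ethoxyphenyl)amino group, gives 780 nM, though it differs from compound 3 in a second place as well. On that basis the expected step is a 2.9-fold lower number from compound 3 to compound 4 (0.46 log units; beyond the scatter), towards a lower number, with wide uncertainty. Estimated value for compound 4: 1500 nM, range 600 nM to 4000 nM.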

Compound 4, half-maximal inhibitory concentration: 420 nM
The estimate for compound 4 lay 3.6-fold (0.55 log units) above the measured number; measured number outside the range, below it.
By their numbers in this assay, from the lowest: compounds 4 and 1 (each within the scatter of the next); then compounds 2 and 3 (each within the scatter of the next).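

Ethoxy at this position separates clearly from both halogens in this assay with a 10-fold lower number from compound 3 to compound 4 (1.02 log units; beyond the scatter) against bromo and a 7.1-fold lower number from compound 2 to compound 4 (0.85 log units; beyond the scatter) against chloro, whereas the earlier halogen exchange alone showed no readable change here. With ethoxy in place, replacing methyl with chloro on the other ring gives only a 1.9-fold lower number from compound 1 to compound 4 (0.27 log units; within the scatter) so the exchange at this position carries far more weight. Nothing measured here bears on the reason for the drop.

As far as these compounds go, whether the result is specific to ethoxy stays open. Methoxy, a longer chain such as butoxy, or an amine at this position would test that.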